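A few compounds are considered here, and "the series" means these few. Any claim that something is new, unique, unknown or untested is made for them only; others in the source may bear on it.

Measured in a functional assay on HCT-15 cells (Homo sapiens) for cytotoxicity, read by colorimetric assay and MTT assay; a higher number here means a weaker inhibitor, a lower number a stronger inhibitor:
- compound 1 (`COc1ccc(-c2cc3cccc(OC)c3nc2O)cc1`): 10000 nM
- compound 2 (`COc1ccc(-c2cc3c(OC)ccc(OC)c3nc2O)cc1`): 10000 nM
- compound 3 (`CCN(CC)C(=O)Cn1c(=O)c(-c2ccc(OC)cc2)cc2c(OC)cc(OC)cc21`): 10000 nM

Level with compound 1 and compound 2, compound 3 stands at 10000 nM in this assay. Compound 4 (`COc1ccc(-c2cc3c(OC)cc(OC)cc3n(CC(=O)O)c2=O)cc1`) carries hydroxy in place of diethylamino on a carbonyl carbon, which turns diethylcarbamoyl into carboxy: hydroxy in place of diethylamino on a carbonyl carbon. Among the compounds with values here, no measured step covers this change. Within the data shown here, the one measured step (no change at the digits printed from compound 1 to compound 2 (within the scatter)) is methoxy in place of hydrogen on an aromatic carbon, so it bears only loosely. No step beyond the scatter is therefore expected, and the expected step is no change at the digits printed from compound 3 to compound 4 (within the scatter). Compound 4 is estimated at 10000 nM, with an expected range of 5000 nM to 20000 nM.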

Compound 4, half-maximal inhibitory concentration: 10000 nM
Compound 4: the middle estimate sits on the measured number at the digits printed; the range from low to high includes it.
By their numbers in this assay, from the lowest: compounds 1, 2, 3 and 4 (each within the scatter of the next).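

In this assay, hydroxy in place of diethylamino on a carbonyl carbon gives no change at the digits printed from compound 3 to compound 4 (within the scatter). This change, diethylcarbamoyl to carboxy, shows that the value holds at this position when the diethylamino group is exchanged, whereas the step between compound 1 and compound 2 covered only methoxy on an aromatic carbon. No measured evidence bears on this result.

Still open, going by these compounds, is whether any group on this carbonyl carbon, such as a methyl ester or an amide carrying a longer chain or a basic amine, would move the value away from that of compound 4.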